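A few compounds are considered here, and "the series" means these few. Any claim that something is new, unique, unknown or untested is made for them only; others in the source may bear on it.

Three compounds have been measured so far in a functional assay on A-375 cells (Homo sapiens) for cytotoxicity, read by MTT assay, with a stated time of 72 h (on this read-out higher numbers stand for weaker inhibition and lower numbers for stronger inhibition), as follows:

- Compound 1 (`O=C1c2c[n+]([O-])c3ccccc3c2C(=O)c2c1c1ccccc1n2Cc1cn([C@H]2O[C@H](CO)[C@@H](O)[C@H]2O)nn1`) gives 340 nM
- Compound 2 (`O=C1c2c[n+]([O-])c3ccccc3c2C(=O)c2c1c1ccccc1n2Cc1cn(CC(O)CO)nn1`) gives 440 nM
- Compound 3 (`O=C1c2c[n+]([O-])c3ccccc3c2C(=O)c2c1c1ccccc1n2CCCCN1CCCCC1`) gives 190 nM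

Compound 3, at 190 nM in this assay, lies within the scatter of compound 1 and apart from compound 2, the gap being a 2.3-fold lower number from compound 2 to compound 3 (0.36 log units; beyond the scatter) on the data so far.

Compound 4 (`CN1CCN(CCCCCn2c3c(c4ccccc42)C(=O)c2c[n+]([O-])c4ccccc4c2C3=O)CC1`) has not yet been measured. It differs from compound 3 thus: (4-methylpiperazin-1-yl)methyl in place of piperidin-1-yl on a saturated chain carbon, four bonds along the chain from an aromatic nitrogen with (4-methylpiperazin-1-yl)methyl in place of piperidin-1-yl on a saturated chain carbon, four bonds along the chain from an aromatic nitrogen.

For the measured compounds named here, two measured steps bear on this only loosely. One is the modest side-chain exchange, a 2.3-fold lower number from compound 2 to compound 3 (0.36 log units; beyond the scatter) and the other is a 1.3-fold higher number from compound 1 to compound 2 (0.11 log units; within the scatter) which stays within the scatter. Going by the values given here, neither makes this exact change, so the data hold no direct precedent. No step beyond the scatter is therefore expected in this assay for this smaller exchange. The estimated step is a 1.2-fold higher number from compound 3 to compound 4 (0.08 log units; within the scatter) and it is uncertain. Compound 4 is expected at about 230 nM within an estimated range of 90 nM to 550 nM in this read-out.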

Compound 4, half-maximal inhibitory concentration: 1710 nM
Compound 4: middle estimate off by 7.4-fold (0.87 log units), on the low side, and the stated range ends below it.
By their numbers in this assay, from the lowest: compounds 3, 1 and 2 (each within the scatter of the next, the first and the last beyond it); then compound 4.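

In this assay, the exchange of piperidin-1-yl for (4-methylpiperazin-1-yl)methyl, on a saturated chain carbon, four bonds along the chain from an aromatic nitrogen, gives a 9.0-fold higher number from compound 3 to compound 4 (0.95 log units; beyond the scatter), the largest step among these compounds, so this position is sensitive to a change that adds only a little to the side chain. The same side chain also compares poorly with the 1-(2,3-dihydroxypropyl)-1H-1,2,3-triazol-4-yl group, with a 3.9-fold higher number from compound 2 to compound 4 (0.59 log units; beyond the scatter), which shows that a saturated nitrogen ring at the chain end does not by itself keep the number low. Nothing available accounts for these steps.

Chain length and ring change together here, so it remains open whether a 4-(piperidin-1-yl)butyl or a 3-(4-methylpiperazin-1-yl)propyl chain would read like compound 3 or like compound 4. From the compounds shown here alone, how a morpholin-4-yl group would read at this place also remains open.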